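From Methylpiperazine to Amino: Estimating Compound 4

The source may report more compounds than this note shows. Statements on the series, on what has been measured and on what is new or still open speak of the compounds shown alone.

Within the data shown here, compound 2 `C=CC(=O)Nc1cc(N)nc(Sc2c(OC)nc(N3CCN(C)CC3)nc2OC)n1` gives 800 nM in a functional assay on SK-BR-3 cells (Homo sapiens) for inhibition, read by resazurin assay, with a stated time of 72 h (a lower number here means a stronger inhibitor, a higher number a weaker inhibitor), the lowest of the three numbers measured so far. Compound 3 `C=CC(=O)Nc1ccnc(Sc2c(OC)nc(N3CCN(C)CC3)nc2OC)n1`, which carries hydrogen in place of amino on an aromatic carbon, gives 1200 nM in this assay; that change is a 1.5-fold higher number from compound 2 to compound 3 (0.18 log units; within the scatter). Compound 1 `C=CC(=O)Nc1cc(N)nc(Sc2c(OC)nc(N3CCCCC3)nc2OC)n1` carries piperidin-1-yl where compound 2 has 4-methylpiperazin-1-yl. In this assay compound 1 gives 9000 nM, and an 11-fold lower number from compound 1 to compound 2 (1.05 log units; beyond the scatter) shows how strongly that one position can move the number.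

Compound 4 `C=CC(=O)Nc1cc(N)nc(Sc2c(OC)nc(N)nc2OC)n1` has not yet been measured. It differs from compound 2 in a single place: amino in place of 4-methylpiperazin-1-yl on an aromatic carbon. Among the measured compounds shown here, the only measured step touching that position is an 11-fold lower number from compound 1 to compound 2 (1.05 log units; beyond the scatter), which was large, while a 1.5-fold higher number from compound 2 to compound 3 (0.18 log units; within the scatter) sits elsewhere and was small. The new group is unlike either measured change in kind, so the direction is uncertain, but a sizeable move is plausible given how sensitive this position proved. Compound 4 is therefore expected to give 3000 nM in this assay, with a range from 500 nM to 20000 nM. That estimate corresponds to an expected step of a 3.8-fold higher number from compound 2 to compound 4 (0.57 log units; beyond the scatter).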

Compound 4, half-maximal inhibitory concentration: 3200 nM
Compound 4: middle estimate off by 1.1-fold (0.03 log units), on the low side, and the stated range covers the measured number.
By their numbers in this assay, from the lowest: compounds 2 and 3 (each within the scatter of the next); then compound 4; then compound 1.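

In this assay, among these compounds, this position had so far been seen only with a ring group attached, and removing the whole ring in favour of a bare amino still leaves a number lying between those of the two ring compounds (a 4.0-fold higher number from compound 2 to compound 4 (0.60 log units; beyond the scatter); a 2.8-fold lower number from compound 1 to compound 4 (0.45 log units; beyond the scatter)). A ring at this position is therefore not required for a number in this range. Group size alone also fails to order the three compounds, as the two ring groups stand at opposite ends with amino in the middle, and nothing shown here explains this order.

The compounds shown leave open which part of 4-methylpiperazin-1-yl separates compound 2 from the piperidine-bearing compound 1: a piperazin-1-yl ring without the methyl group, or a morpholin-4-yl ring with an oxygen in place of the second ring nitrogen, would help to tell the methyl group and that nitrogen apart. Also open, as far as these compounds go, is the ground between amino and a full ring, where a dimethylamino group or a short chain ending in an amine could show whether the number changes gradually or only once the ring is present.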